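Solubility of a Fluorophenyl Urea Estimated from Three Analogues

The source may hold more compounds than are shown below. What is called first, only, known or untested is meant among the compounds shown, and "the series" means these compounds.

Three compounds have been measured in a physicochemical assay for solubility, at pH 7.4; a lower number here means a less soluble compound, a higher number a more soluble compound:
compound 1 `COc1ccc(NC(=O)Nc2cc(C)nc3ccccc23)cc1` gives 19800 nM;
compound 2 `Cc1cc(NC(=O)Nc2ccc(O)cc2)c2ccccc2n1` gives 100 nM;
compound 3 `CSc1ccc(NC(=O)Nc2cc(C)nc3ccccc23)cc1` gives 1300 nM.

Compound 2 stands lowest of the three: the nearest number is reached by a 13-fold higher number from compound 2 to compound 3 (1.11 log units; beyond the scatter), and the widest gap is a 200-fold lower number from compound 1 to compound 2 (2.30 log units; beyond the scatter). Compound 4 `Cc1cc(NC(=O)Nc2cccc(F)c2)c2ccccc2n1` has not yet been measured. It differs from compound 2 in one place: 3-fluorophenyl in place of 4-hydroxyphenyl on an amide-type nitrogen. For the measured compounds named here, two measured steps bear on this, since each involves the hydroxy that compound 4 also loses: a 200-fold lower number from compound 1 to compound 2 (2.30 log units; beyond the scatter) and a 13-fold higher number from compound 2 to compound 3 (1.11 log units; beyond the scatter). In both, the compound carrying the hydroxy gave the lower number, so a large rise is expected for compound 4 in this assay, a 20-fold higher number from compound 2 to compound 4 (1.30 log units; beyond the scatter). Compound 4 is therefore estimated at 2000 nM, within a range of 400 nM to 10000 nM.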

Compound 4, solubility: 100 nM
Beside the measured number, compound 4's estimate is 20-fold (1.30 log units) above it, and the stated range ends above it.
By their numbers in this assay, from the lowest: compounds 2 and 4 (each within the scatter of the next); then compound 3; then compound 1.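

In this assay replacing 4-hydroxyphenyl with 3-fluorophenyl gives no change at the digits printed from compound 2 to compound 4 (within the scatter) and so removing the hydroxy does not by itself lift the number at this position. The earlier compounds shown here showed only methoxy and methylsulfanyl taking the place of hydroxy, whereas compound 4 has no hydroxy and still does not rise. Nothing available explains this result.

This single change alters both the group and its place on the ring, so the two effects cannot be separated. From the compounds shown here alone, how an amine or a carboxylic acid on this ring would read also remains open.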